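Thiophene-fused series: ortho chloro added to compound 3

This account rests on a few compounds, and the source may have more. Where it says the series, first, only, none or still open, it means among the compounds named here.

Measured in a functional assay on HT-29 cells (Homo sapiens) for cytotoxicity, read by MTT assay, with a stated time of 72 h; a lower number here means a stronger inhibitor, a higher number a weaker inhibitor:
- compound 1 `CN(C)CCCNc1nc(-c2ccc(NC(=O)Nc3ccc(Cl)cc3Cl)cc2)nc2ccsc12`: 1860 nM
- compound 2 `CCN(CC)CCNc1nc(-c2ccc(NC(=O)Nc3ccccc3F)cc2)nc2ccsc12`: 610 nM
- compound 3 `CCN(CC)CCNc1nc(-c2ccc(NC(=O)Nc3ccc(Cl)cc3)cc2)nc2ccsc12`: 150 nM

Compound 3 holds the lowest number of the three; compound 2 sits a step away a 4.1-fold lower number from compound 2 to compound 3 (0.61 log units; beyond the scatter), and compound 1 further still. Compound 4 `CCN(CC)CCNc1nc(-c2ccc(NC(=O)Nc3ccc(Cl)cc3Cl)cc2)nc2ccsc12` is not yet measured. It differs from compound 3 by chloro in place of hydrogen on an aromatic carbon, placed on an aromatic carbon of a six-membered aromatic ring of carbon only, ortho to a large group and meta to a chloro group.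

Among the measured compounds shown here, no measured step reproduces this change directly. For the measured compounds named here, the single step in hand, a 4.1-fold lower number from compound 2 to compound 3 (0.61 log units; beyond the scatter), exchanges one aryl group for another and only shows that the urea aryl ring moves the number well beyond the scatter. Compound 1 carries the same 2,4-dichlorophenyl as compound 4 but a different amine, so the pair of values for compound 1 and compound 3 cannot be read as a clean step. The expectation is therefore a weakening, a 4.7-fold higher number from compound 3 to compound 4 (0.67 log units; beyond the scatter), with wide uncertainty. Compound 4 is estimated at 700 nM, within 200 nM to 2500 nM.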

Compound 4, half-maximal inhibitory concentration: 1940 nM
Compound 4: middle estimate off by 2.8-fold (0.44 log units), on the low side; the range from low to high includes it.
By their numbers in this assay, from the lowest: compound 3; then compound 2; then compounds 1 and 4 (each within the scatter of the next).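

In this assay chloro in place of hydrogen, ortho to a large group on the 4-chlorophenyl ring, gives a 13-fold higher number from compound 3 to compound 4 (1.11 log units; beyond the scatter) and so marks this position as highly sensitive within the series. Set against the 2-fluorophenyl group, 2,4-dichlorophenyl gives a 3.2-fold higher number from compound 2 to compound 4 (0.50 log units; beyond the scatter) and so also falls short of the earlier aryl exchange that led to compound 3. With 2,4-dichlorophenyl held constant, diethylamino in place of (dimethylamino)methyl gives a 1.0-fold higher number from compound 1 to compound 4 (0.02 log units; within the scatter) and leaves no readable difference in this single pair.

No measurement in hand bears on why the added chloro raises the number. Still open, on these data alone, is whether methyl or methoxy ortho to the large group would follow chloro, and whether a morpholine in place of diethylamino would change the number on the 4-chlorophenyl compound.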